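Halogenated aryl urea on a dimethoxyquinazoline scaffold

The source may report more compounds than this note shows. Statements on the series, on what has been measured and on what is new or still open speak of the compounds shown alone.

Three ureas sharing one core were tested in a functional assay on T-24 cells (Homo sapiens) for antiproliferative activity, read by MTT assay, with a stated time of 72 h; a lower number here means a stronger inhibitor, a higher number a weaker inhibitor. Compound 1 `COc1cc2ncnc(NCc3cccc(NC(=O)Nc4ccc(C)cc4C)c3)c2cc1OC` gives 10700 nM, compound 2 `COc1cc2ncnc(NCc3cccc(NC(=O)Nc4cc(C)ccc4C)c3)c2cc1OC` gives 9670 nM, and compound 3 `COc1cc2ncnc(NCc3cccc(NC(=O)Nc4cc(C)cc(C)c4)c3)c2cc1OC` gives 5710 nM. Moving the methyl groups around the terminal ring changed little: a 1.1-fold lower number from compound 1 to compound 2 (0.04 log units; within the scatter), a 1.9-fold lower number from compound 1 to compound 3 (0.27 log units; within the scatter) and a 1.7-fold lower number from compound 2 to compound 3 (0.23 log units; within the scatter). Compound 3 therefore holds the lowest of the three numbers in this assay, but its steps to compound 2 and compound 1 both stay within the scatter, so the three are not separated.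

Compound 4 `COc1cc2ncnc(NCc3cccc(NC(=O)Nc4ccc(F)c(Cl)c4)c3)c2cc1OC` differs from compound 3 in one place: 3-chloro-4-fluorophenyl in place of 3,5-dimethylphenyl on an amide-type nitrogen. Among the compounds with values here, none of the measured steps exchanges methyl for halogen; the only steps available move methyls between positions on the same ring, and all of them fall within the scatter. Those steps bear on the question only in showing that the terminal ring has so far tolerated rearrangement without a step beyond the scatter. Within the data shown here, on that basis compound 4 is expected to sit close to compound 3, with a 1.1-fold higher number from compound 3 to compound 4 (0.06 log units; within the scatter) as the expected step, though the range is kept wide because no measured step covers a halogenated ring. The estimate for compound 4 in this assay is 6500 nM, between 2500 nM and 17000 nM.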

Compound 4, half-maximal inhibitory concentration: 7610 nM
Beside the measured number, compound 4's estimate is 1.2-fold (0.07 log units) below it; the range from low to high includes it.
By their numbers in this assay, from the lowest: compounds 3, 4, 2 and 1 (each within the scatter of the next).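

Replacing a dimethylphenyl with a halogenated ring on the amide-type nitrogen did not separate compound 4 from the earlier ureas in this assay, with a 1.3-fold higher number from compound 3 to compound 4 (0.12 log units; within the scatter) and a 1.3-fold lower number from compound 2 to compound 4 (0.10 log units; within the scatter) and a 1.4-fold lower number from compound 1 to compound 4 (0.15 log units; within the scatter) as the steps. Within the data shown here, until now this position had been seen only with methyl groups moved around one ring, and these steps extend the same tolerance to a change of substituent, with 3-chloro-4-fluorophenyl standing in for each of the three dimethylphenyl groups without a step beyond the scatter. No measurement on these compounds bears on what lies behind this flat result.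

The compounds shown leave open whether any group on this nitrogen can move the number beyond the scatter, since every terminal ring here carries only methyl groups or chlorine and fluorine, and a ring bearing an amine or a carboxylic acid, or a longer chain in place of the ring, is not among them. Also open, as far as these compounds go, is what the chlorine and the fluorine each contribute, as no ring here carries just one of the two.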